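A few compounds are considered here, and "the series" means these few. Any claim that something is new, unique, unknown or untested is made for them only; others in the source may bear on it.

Measured compounds in a functional assay on NCI-H23 cells (Homo sapiens) for cytotoxicity, read by sulforhodamine B assay, with a stated time of 48 h, tested at 0.01 uM; on this read-out lower numbers stand for a stronger effect and higher numbers for a weaker effect at the one concentration tested:
compound 1 `COc1cc(C)cc(-c2c(-c3ccnc(-c4ccc(C(C)=O)cc4)c3)cnn2CC#N)c1`: 95%
compound 2 `Cc1cc(O)cc(-c2nn(CC#N)cc2-c2ccnc(-c3ccc(Oc4ccccc4)cc3)c2)c1`: 93%
compound 3 `Cc1cc(O)cc(-c2nn(CC#N)cc2-c2ccnc(-c3ccc(N(C)C)cc3)c2)c1`: 96%

Compound 1 stands second highest of the three numbers. Compound 3 lies nearest to it and compound 2 furthest, and both gaps fall within the scatter, so the three measured compounds cannot be put in any order on this read-out; all of them sit near the weak end of the scale.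

The step under study leads from compound 1 to compound 4 `COc1cc(C)cc(-c2c(-c3ccnc(-c4ccc(N(C)C)cc4)c3)cnn2CC#N)c1`: dimethylamino in place of acetyl on an aromatic carbon

For the measured compounds named here, only one measured step touches the entering group: a number 3 percentage points higher from compound 2 to compound 3 (within the scatter), where dimethylamino likewise entered on an aromatic carbon, and the read-out stayed within the scatter. Going by the values given here, the leaving group there was phenoxy rather than acetyl, so the two steps are not the same, and no measured pair shows acetyl leaving. Compound 1 and compound 3, which differ in more than one place, also give numbers within the scatter of each other. On this basis no change beyond the scatter is expected in this assay, and the step expected is no change at the digits printed from compound 1 to compound 4 (within the scatter). Compound 4 is therefore estimated to give 95% in this assay, within 87% to 100%.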

Compound 4, a percentage reported as activity, at one concentration (the size of the read-out at that concentration, not a potency): 67%
Beside the measured number, compound 4's estimate is 28 percentage points above it; measured number below the stated range.
By their numbers in this assay, from the lowest: compound 4; then compounds 2, 1 and 3 (each within the scatter of the next).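

In this assay the change from 4-acetylphenyl to 4-(dimethylamino)phenyl gives a number 28 percentage points lower from compound 1 to compound 4 (beyond the scatter), the only listed step that lies beyond the scatter, so this position can move the read-out even when the two groups match in heavy-atom count and hydrogen-bond acceptor count. Dimethylamino entering in place of phenoxy gives a number 3 percentage points higher from compound 2 to compound 3 (within the scatter), so the entering group does not lower the number in both settings, and the outcome depends on the group that leaves, on the rest of the compound, or on both. No measurement at hand bears on the reason for the step in compound 4.

Going by these compounds, whether the step comes from the loss of acetyl or from the arrival of dimethylamino stays open, as a single pair cannot separate the two. Also open, on these data alone, is how the read-out at this position responds to other nitrogen groups on the core of compound 1, such as a primary amine, diethylamino or a morpholine ring, and whether a carboxylic acid there gives a number closer to that of compound 1.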